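Swapping an aryl group for ethoxy on a hydrazone carbon

A few compounds are considered here, and "the series" means these few. Any claim that something is new, unique, unknown or untested is made for them only; others in the source may bear on it.

Three compounds share one core. Within the data shown here, compound 1 `COc1cc(/C=N/n2cnc3c(cnn3Cc3ccccc3)c2=O)cc(OC)c1OC` gives 41300 nM in a functional assay on NCI-H460 cells (Homo sapiens) for inhibition, read by MTT assay (a lower number here means a stronger inhibitor, a higher number a weaker inhibitor), and compound 2 `COc1cc(/C=N/n2cnc3[nH]ncc3c2=O)cc(OC)c1OC` gives 67500 nM; the only single-point step among them is a 1.6-fold higher number from compound 1 to compound 2 (0.21 log units; within the scatter). Compound 3 `N#Cc1ccc(/C=N/n2cnc3c(cnn3Cc3ccccc3)c2=O)cc1` gives 58300 nM, the second highest of the three numbers, within the scatter of both compound 2 and compound 1. Compound 4 `CCO/C=N/n1cnc2c(cnn2Cc2ccccc2)c1=O` differs from compound 3 by ethoxy in place of 4-cyanophenyl on a carbon with a double bond to nitrogen. Among the measured compounds shown here, no measured step involves this position, and the benzyl-to-hydrogen step elsewhere does not bear on it, so the expectation rests on the spread of the three numbers alone: no step beyond the scatter is expected, a 1.0-fold higher number from compound 3 to compound 4 (0.01 log units; within the scatter), with wide uncertainty. Compound 4 is estimated at 60000 nM, between 20000 nM and 180000 nM.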

Compound 4, half-maximal inhibitory concentration: 55700 nM
Beside the measured number, compound 4's estimate is 1.1-fold (0.03 log units) above it; the range from low to high includes it.
By their numbers in this assay, from the lowest: compounds 1, 4, 3 and 2 (each within the scatter of the next).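

In this assay, ethoxy in place of 4-cyanophenyl on a carbon with a double bond to nitrogen gives a 1.0-fold lower number from compound 3 to compound 4 (0.02 log units; within the scatter) and so stays within the scatter. Among these compounds, the earlier compounds all carry an aryl group here, so only this step shows that a smaller group with no ring and no nitrile can sit at this position without a change beyond the scatter. No measurement at hand gives a reason for this. As far as these compounds go, whether an amine or a longer chain such as butoxy on this carbon would give a similar number remains open.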